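The source may report more compounds than this note shows. Statements on the series, on what has been measured and on what is new or still open speak of the compounds shown alone.

Measured compounds in a functional assay on MCF7 cells (Homo sapiens) for inhibition, read by MTT assay, with a stated time of 72 h; on this read-out higher numbers stand for weaker inhibition and lower numbers for stronger inhibition:

Compound 1 `Cc1ccc(-n2cc(CNC(=O)c3cccc4c3cnn4C(C)C)nn2)cc1` — in this assay compound 1 gives > 40000 nM, which is a limit of the assay and not a number.
Compound 2 `Cc1cccc(-n2cc(CNC(=O)c3cccc4c3cnn4C(C)C)nn2)c1` — in this assay compound 2 gives > 40000 nM, also a limit.
Compound 3 `CC(C)n1ncc2c(C(=O)NCc3cn(-c4ccccc4F)nn3)cccc21` — in this assay compound 3 gives > 40000 nM, again a limit.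

Compound 3 thus stands at the same limit as the other two measured compounds; all three sit at the limit of > 40000 nM in this assay, at which 3 of the 3 values shown sit, so none of them separates from the others on the numbers shown.

Compound 4 `CC(C)n1ncc2c(C(=O)NCc3cn(Cc4ccc(C#N)cc4)nn3)cccc21` differs from compound 3 in one place: 4-cyanobenzyl in place of 2-fluorophenyl on an aromatic nitrogen.

The measured steps on the same aromatic nitrogen are the only ones that bear on this change: a step that the two limits leave unreadable from compound 1 to compound 2, a step that the two limits leave unreadable from compound 1 to compound 3 and a step that the two limits leave unreadable from compound 2 to compound 3. None of them is readable, since every value involved is a limit. Going by the values given here, the change to compound 4 is larger than any of these, replacing an aryl group directly on the ring nitrogen with a benzyl group, and no measured compound carries such a group.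

For compound 4 the expectation is therefore 50000 nM, with the range 15000 nM to 200000 nM, most likely reported as a limit again. The step from compound 3 that this estimate means, a step that the limit leaves unreadable from compound 3 to compound 4, is expected not to be readable beyond the scatter.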

Compound 4, half-maximal inhibitory concentration: > 40000 nM
Compound 4 gave a limit, no number; the forecaster's own chance of this, stated with the estimate: 75%; the middle value does not contradict the limit.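

In this assay compound 4 gives > 40000 nM, a limit of the assay and not a number. No step from compound 1, compound 2 or compound 3 to compound 4 can be read, because all the values are limits: the limit of > 40000 nM in this assay, at which 4 of the 4 values shown sit.

The compounds shown leave open whether any group on this aromatic nitrogen gives a measurable value in this assay.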